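This account rests on a few compounds, and the source may have more. Where it says the series, first, only, none or still open, it means among the compounds named here.

Compound 1 `Cc1ccc2c(NCc3ccc(NC(=O)C4CCN(Cc5ccccc5)CC4)cc3)nc(N3CCCCCC3)nc2c1`, compound 2 `Cc1ccc2c(NCc3ccc(NC(=O)C4CCN(C5CCCCC5)CC4)cc3)nc(N(C)C)nc2c1` and compound 3 `Cc1ccc2c(NCc3ccc(NC(=O)C4CCN(Cc5ccccc5)CC4)cc3)nc(N(C)CCN(C)C)nc2c1` share one core and differ only in the group on the aromatic carbon and in the substituent on the piperidine nitrogen. In a functional assay on SV5A8 cells (Homo sapiens) for cytotoxicity (a higher number here means a weaker inhibitor, a lower number a stronger inhibitor), compound 1 gives > 6880 nM, which is a limit of the assay and not a number. Compound 2 gives > 8320 nM in this assay, again a limit. Compound 3 gives > 8830 nM, also a limit. Compound 2 therefore stands at a limit, and the two other values shown are limits as well (the limit of > 6880 nM in this assay, at which 1 of the 3 values shown sits, (the limit of > 8320 nM in this assay, at which 1 of the 3 values shown sits), (the limit of > 8830 nM in this assay, at which 1 of the 3 values shown sits)). Among the measured compounds shown here, the one step between measured compounds, a step that the two limits leave unreadable from compound 1 to compound 3, cannot be read for size. Compound 4 `CCCCN1CCC(C(=O)Nc2ccc(CNc3nc(N(C)C)nc4cc(C)ccc34)cc2)CC1` differs from compound 2 by butyl in place of cyclohexyl on an amine nitrogen in a ring. For the measured compounds named here, no measured step bears on this change. Compound 4 is therefore expected to sit near the limit too, estimated at 10000 nM with a range from 3000 nM to 30000 nM. The step that the limit leaves unreadable from compound 2 to compound 4 is expected to be nothing readable beyond the scatter.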

Compound 4, half-maximal inhibitory concentration: > 10500 nM
Compound 4 gave a limit, no number (the forecaster's own chance of this, stated with the estimate: 80%); middle value at least 1.0-fold (0.02 log units) from the limit.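

Compound 2 and compound 4 both stand at limits of this assay, so no size can be read for butyl in place of cyclohexyl. The compounds shown leave open what real half-maximal inhibitory concentration any of them has, and so which group matters here.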